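The source may report more compounds than this note shows. Statements on the series, on what has been measured and on what is new or still open speak of the compounds shown alone.

Three compounds built on one shared core were tested in an ADME assay on HepG2 cells (Homo sapiens) for cytotoxicity, read by sulforhodamine B assay, with a stated time of 48 h; on this read-out lower numbers stand for higher toxicity in this test and higher numbers for lower toxicity in this test. Compound 1 `COc1nc2ccccc2cc1/C=C/c1noc(-c2ccccc2)n1` carries a plain phenyl group; in this assay compound 1 reaches only a limit, > 240000 nM. Compound 2 `COc1ccc(-c2nc(/C=C/c3cc4ccccc4nc3OC)no2)cc1` carries a 4-methoxyphenyl group instead; in this assay compound 2 likewise gives only a limit, > 220000 nM. Compound 3 `COc1nc2ccccc2cc1/C=C/c1noc(-c2cccc(C)c2)n1` carries a 3-methylphenyl group; in this assay compound 3 again gives only a limit, > 230000 nM. Compound 2 thus stands among values that are all limits, with no number to set it apart. The step that the two limits leave unreadable from compound 1 to compound 2 cannot be read, and neither can a step that the two limits leave unreadable from compound 1 to compound 3 nor a step that the two limits leave unreadable from compound 2 to compound 3. Compound 4 `COc1nc2ccccc2cc1/C=C/c1noc(-c2cccc(Cl)c2)n1` has not yet been measured. It differs from compound 2 by 3-chlorophenyl in place of 4-methoxyphenyl on an aromatic carbon. The measured steps that bear on this change are all unreadable and point in no direction, so the step that the limit leaves unreadable from compound 2 to compound 4 is expected to fall within the scatter. Compound 4 is therefore estimated at 230000 nM, with a range from 100000 nM to 500000 nM.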

Compound 4, half-maximal cytotoxic concentration: > 220000 nM
Compound 4 ended at the assay's limit; the forecaster's own chance of this, stated with the estimate: 80%; the middle value does not contradict the limit.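

In this assay compound 4 also gives only a limit, > 220000 nM. Its steps from compound 1, compound 2 and compound 3 therefore cannot be read. The four compounds leave open whether the phenyl, 4-methoxyphenyl, 3-methylphenyl and 3-chlorophenyl groups differ at all in this assay.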